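Swapping the Aromatic Group: Expected Efficacy of Compound 3

A few compounds are considered here, and "the series" means these few. Any claim that something is new, unique, unknown or untested is made for them only; others in the source may bear on it.

Compound 1 `CS(=O)(=O)Nc1cccc(-c2nc(C(c3ccc(F)cc3)c3ccc(F)cc3)sc2CC(=O)O)c1`: 80%
Compound 2 `O=C(O)Cc1sc(C(c2ccc(F)cc2)c2ccc(F)cc2)nc1-c1cn[nH]c1`: 80%

Both compounds were tested in an in vitro functional assay on HEK285-7 cells for antagonist activity at prostaglandin D2 receptor 2 (Homo sapiens), read by BRET and beta-arrestin recruitment; a lower number here means a smaller maximal response, a higher number a larger maximal response. Compound 1 reaches 80% there. Compound 2 reaches 80%, so the two stand level within the usual scatter of this measurement. Going by the values given here, the one measured step, no change at the digits printed from compound 1 to compound 2 (within the scatter), exchanges one aromatic group for another on an aromatic carbon of the shared core without moving the maximal response beyond the scatter.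

Compound 3 `N#Cc1cc(-c2nc(C(c3ccc(F)cc3)c3ccc(F)cc3)sc2CC(=O)O)ccc1F` has not yet been measured. It differs from compound 2 as follows: 3-cyano-4-fluorophenyl in place of 1H-pyrazol-4-yl on an aromatic carbon. Among the compounds with values here, the only step that bears on this change is no change at the digits printed from compound 1 to compound 2 (within the scatter), which showed no shift when the aromatic group on that carbon was exchanged. Because no change at the digits printed from compound 1 to compound 2 (within the scatter) was flat, the step of no change at the digits printed from compound 2 to compound 3 (within the scatter) is expected to be flat as well, with no change beyond the scatter. Compound 3 is therefore estimated to reach about 80%, with a likely range from 65% to 95%.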

Compound 3, largest response reached (reported as efficacy), in percent of the reference or control that the assay uses: 80%
Compound 3: the middle estimate sits on the measured number at the digits printed; low and high end bracket the measured number.
By their numbers in this assay, from the lowest: compounds 1, 2 and 3 (each within the scatter of the next).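

In this assay the new compound brings a larger group to this aromatic carbon: 3-cyano-4-fluorophenyl, with 9 heavy atoms and 0 hydrogen-bond donors, replaces 1H-pyrazol-4-yl, and the result is no change at the digits printed from compound 2 to compound 3 (within the scatter) in the maximal response. Set against the 3-(methanesulfonamido)phenyl group, the same new group gives no change at the digits printed from compound 1 to compound 3 (within the scatter), so three differently built aromatic groups now stand level at this position. Nothing measured here explains why the response stays flat.

All three compounds carry an aromatic ring on this carbon, which leaves open whether a morpholine ring, a primary amine or a short alkyl chain would stand at the same level. Also open, from the compounds shown here alone, is how the response would move with an amide in place of the carboxylic acid.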